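This account rests on a few compounds, and the source may have more. Where it says the series, first, only, none or still open, it means among the compounds named here.

Measured compounds:
- compound 1 `O=C(/C=C/[C@H]1C[C@@H](O)[C@@H](O)C1)Nc1ccc(F)cc1`: in an ADME assay on S2 cells (Drosophila melanogaster) for cytotoxicity, read by MTT assay (a higher number here means that more compound is needed for the effect, a lower number that less compound is needed), compound 1 gives > 180000 nM, which is a limit of the assay and not a number.
- compound 2 `CC(=O)c1ccc(NC(=O)/C=C/[C@H]2C[C@@H](O)[C@@H](O)C2)cc1`: compound 2 gives > 180000 nM, again a limit of the assay and not a number.

Compound 2 stands at the edge of what this assay can read; both measured values sit there, as the limit of > 180000 nM in this assay, at which 2 of the 2 values shown sit, records. Going by the values given here, the single measured step, a step that the two limits leave unreadable from compound 1 to compound 2, is accordingly unreadable: two limits cannot show whether the substitution moved anything at all. Compound 3 `O=C(/C=C/[C@H]1C[C@@H](O)[C@@H](O)C1)Nc1ccc([N+](=O)[O-])cc1` is the next member of the series; (nitro in place of acetyl on an aromatic carbon). Among the compounds with values here, the only step that bears on this change is the unreadable one between the measured pair, so no size and no direction can be taken from it, and nothing so far has returned a number inside the readable range. For compound 3 the expected step is a step that the limit leaves unreadable from compound 2 to compound 3, meaning no change beyond the scatter is expected and a further limit is the most likely outcome. Compound 3 is estimated at 250000 nM in this assay, with a range from 90000 nM to 1000000 nM.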

Compound 3, half-maximal effective concentration: > 170000 nM
Compound 3: a limit, no number; the forecaster's own chance of this, stated with the estimate: 85%; the middle value lies beyond the limit too.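

Going by these compounds alone, compound 1, compound 2 and compound 3 all give limits of the assay and not numbers in this assay, and no step among them can be read. The compounds shown leave open whether fluoro, acetyl and nitro on the aromatic carbon differ at all in this assay, and what concentration any of the three would need for the effect.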